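Removing a Chloro Group on Two Different Cores

The source may hold more compounds than are shown below. What is called first, only, known or untested is meant among the compounds shown, and "the series" means these compounds.

The measured compounds are:
compound 1 `O=C(/C=C/c1ccc(Cl)cc1)Nc1nc2ccccc2s1`, 367 umol/kg
compound 2 `O=C(/C=C/c1ccc(Cl)cc1)Nc1nc2ccc(Cl)cc2s1`, 204 umol/kg
compound 3 `CC(=O)N1N=C(Nc2nc3ccc(C)cc3s2)CC1c1ccc(Cl)cc1`, 25.5 umol/kg

In a functional assay on the whole organism (Hindlimb, strain albino) with Mus musculus as the target, in the maximal electroshock model, with a stated time of 0.5 h (a lower number here means that less compound is needed, a higher number that more compound is needed for the effect), compound 3 gives 25.5 umol/kg, the lowest of the three numbers, while compound 2 gives 204 umol/kg and compound 1 gives 367 umol/kg. The difference between the core of compound 3 and that of compound 2 is not broken down here.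

Between compound 2 and compound 1 the change is hydrogen in place of chloro on an aromatic carbon, and in this assay it gave a 1.8-fold higher number from compound 2 to compound 1 (0.26 log units; within the scatter). The unmeasured compound 4 `CC(=O)N1N=C(Nc2nc3ccc(C)cc3s2)CC1c1ccccc1` stands to compound 3 as hydrogen in place of chloro on an aromatic carbon. This is the same kind of change, but not the same: in compound 2 the chloro sits on a ring that is part of a fused system, meta and para to a fused ring, whereas in compound 3 it sits on a six-membered aromatic ring of carbon only, para to a large group.

Because the earlier step was a 1.8-fold higher number from compound 2 to compound 1 (0.26 log units; within the scatter), compound 4 is expected to show a similarly small rise, a 1.6-fold higher number from compound 3 to compound 4 (0.20 log units; within the scatter). The estimate for compound 4 is 40 umol/kg, between 15 umol/kg and 110 umol/kg.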

Compound 4, dose for half-maximal effect: 106 umol/kg
Estimate against measurement, compound 4: 2.7-fold (0.42 log units) below, within the range that was stated.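

In this assay, going from 4-chlorophenyl to phenyl gave a 4.2-fold higher number from compound 3 to compound 4 (0.62 log units; beyond the scatter), so on this core the compound carrying the chloro group needs the smaller dose. For the compounds shown here, only this step lies beyond the scatter, yet the two steps on the two cores cannot be told apart: the same change on two cores in this assay, a 1.8-fold higher number (0.26 log units; within the scatter) from compound 2 to compound 1 and a 4.2-fold higher number (0.62 log units; beyond the scatter) from compound 3 to compound 4, 2.3-fold (0.36 log units) apart, within the scatter of two such steps. This fits a change that carries over between these two cores, but with a single pair on each core it does not fix the size of the step, does not show that the step would hold on any other core, and gives no reason for it.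

The compounds shown leave open whether another group in the same place on the phenyl ring, such as fluoro, methoxy or an amine, would give a number like that of compound 3. They also leave open how chloro or hydrogen in place of the methyl group on the core of compound 3 would read in this model.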